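The source may hold more compounds than are shown below. What is called first, only, known or untested is meant among the compounds shown, and "the series" means these compounds.

In a functional assay on ECa-109 cells for inhibition, with ECa-109 cell line (Homo sapiens) as the target, read by sulforhodamine B assay (a higher number here means a weaker inhibitor, a lower number a stronger inhibitor), compound 1 `O=C1C(Nc2ccccc2)=CC(=O)c2c1nc1n2[C@H]2OC[C@@H](O)[C@H]2OC1` gives 3560 nM. Compound 2 `CCc1ccc(NC2=CC(=O)c3c(nc4n3[C@H]3OC[C@@H](O)[C@H]3OC4)C2=O)cc1` reads > 4000 nM, which is a limit of the assay and not a number. Compound 3 `O=C1C(N2CCC2)=CC(=O)c2c1nc1n2[C@H]2OC[C@@H](O)[C@H]2OC1` reads > 16000 nM, and this too is only a limit. Compound 4 `O=C1C(NC2CCCCC2)=CC(=O)c2c1nc1n2[C@H]2OC[C@@H](O)[C@H]2OC1` has cyclohexylamino in place of azetidin-1-yl on a double-bonded ring carbon. The nearest measured change, azetidin-1-yl in place of anilino, gave an at least 4.4-fold higher number from compound 1 to compound 3 (0.65 log units; beyond the scatter). Adding ethyl gave an at least 1.1-fold higher number from compound 1 to compound 2 (0.05 log units; that floor lies within the scatter), and a step that the two limits leave unreadable from compound 2 to compound 3 adds nothing further. Cyclohexylamino resembles the anilino of compound 1 at 3560 nM, so a partial return toward that number is expected. The expected step is an at least 2.9-fold lower number from compound 3 to compound 4 (0.46 log units; beyond the scatter). For compound 4 the estimate is 5500 nM, with an expected range from 2000 nM to 15000 nM.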

Compound 4, half-maximal inhibitory concentration: > 16000 nM
Compound 4 gave a limit, no number; the forecaster's own chance of this, stated with the estimate: 30%; middle value at least 2.9-fold (0.46 log units) away from the limit.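

On the amine nitrogen, cyclohexyl in place of phenyl gives an at least 4.4-fold higher number from compound 1 to compound 4 (0.65 log units; beyond the scatter), so a non-aromatic ring that keeps the amine hydrogen, which azetidin-1-yl lacks, does not restore the reading of compound 1. Compound 4 has a limit and not a number, the same limit as compound 3: the limit of > 16000 nM in this assay, at which 2 of the 4 values shown sit. The steps from compound 2 and from compound 3 to compound 4 cannot be read. Still open, from the compounds shown here alone, is how far these compounds lie past their limits, and whether benzylamino or a butylamino chain on this carbon would read nearer to compound 1.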